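Amine swap on the chain: compound 2 to compound 3

The source may report more compounds than this note shows. Statements on the series, on what has been measured and on what is new or still open speak of the compounds shown alone.

Among the compounds with values here, compound 2 `CCN(CC)CCCCCOc1ccc(C(=O)/C=C/c2ccccc2)cc1` gives 1.84 in a physicochemical assay for lipophilicity, using the shake flask method, measured as octanol-water partition, at pH 7.4 (on this read-out lower numbers stand for lower lipophilicity and higher numbers for higher lipophilicity), the lowest of the two numbers so far; compound 1 `CCCCN(CCCC)CCCCOc1ccc(C(=O)/C=C/c2ccccc2)cc1` gives 2.09, and the two lie within the scatter of each other. Compound 3 `CCCCN(CCCC)CCCCCOc1ccc(C(=O)/C=C/c2ccccc2)cc1` differs from compound 2 by dibutylamino in place of diethylamino on a saturated chain carbon, five bonds along the chain from an oxygen on an aromatic ring. Within the data shown here, the one measured step that bears on this, a number 0.25 log units lower from compound 1 to compound 2 (within the scatter), combines the amine swap in the opposite direction with a chain one bond longer and stays within the scatter. Because a number 0.25 log units lower from compound 1 to compound 2 (within the scatter) was small, only a modest upward step is expected, a number 0.51 log units higher from compound 2 to compound 3 (beyond the scatter). Compound 3 is estimated at 2.35, range 1.9 to 2.9.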

Compound 3, partition coefficient: 2.14
Compound 3: middle estimate off by 0.21 log units, on the high side; the measured number falls inside the stated range.
By their numbers in this assay, from the lowest: compounds 2, 1 and 3 (each within the scatter of the next).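

In this assay dibutylamino in place of diethylamino on a saturated chain carbon, five bonds along the chain from an oxygen on an aromatic ring, gives a number 0.30 log units higher from compound 2 to compound 3 (within the scatter) and so reads the amine change with the chain held constant. With dibutylamino kept, (dibutylamino)methyl in place of dibutylamino gives a number 0.05 log units higher from compound 1 to compound 3 (within the scatter) and so reads the chain change apart from the amine change. Neither single change at this position clears the scatter.

Going by these compounds, whether a cyclic amine such as piperidine or a longer chain would give a step beyond the scatter remains open. No measured evidence accounts for these numbers.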